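The source may report more compounds than this note shows. Statements on the series, on what has been measured and on what is new or still open speak of the compounds shown alone.

Series notes. Compound 1 `CCC1(c2ccccc2)CC(=O)C(C(CC(=O)c2ccc(-c3ccc(Br)cc3)cc2)c2ccccc2)=C(O)O1` and compound 2 `CCCC1(c2ccccc2)CC(=O)C(C(CC(=O)c2ccc(-c3ccc(Br)cc3)cc2)c2ccccc2)=C(O)O1` share one core; compound 3 `CC1(c2ccccc2)CC(=O)C(C2CC(c3ccc(-c4ccc(Br)cc4)cc3)Cc3ccccc32)=C(O)O1` and compound 4 `CCC1(c2ccccc2)CC(=O)C(C2CC(c3ccc(-c4ccc(Br)cc4)cc3)Cc3ccccc32)=C(O)O1` share another. How the two cores differ is not broken down here.

In a functional assay on HCT-15 cells (Homo sapiens) for inhibition, with a stated time of 72 h (on this read-out lower numbers stand for stronger inhibition and higher numbers for weaker inhibition), compound 1 gives 6710 nM. For compound 2 the read-out in this assay is a limit of the assay, > 10000 nM, as stated under (the limit of > 10000 nM in this assay, at which 1 of the 3 values shown sits). The change from compound 1 to compound 2 is methyl in place of hydrogen on a saturated chain carbon, two bonds along the chain from a saturated ring carbon, and it gave an at least 1.4-fold higher number from compound 1 to compound 2 (0.17 log units; that floor lies within the scatter). Compound 3 gives 1310 nM in this assay, the lowest of the two numbers recorded so far.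

Compound 4 differs from compound 3 by methyl in place of hydrogen on a saturated chain carbon bound to a saturated ring carbon. This is the same kind of change as that from compound 1 to compound 2, but the place differs: there the methyl enters two bonds along the chain from a saturated ring carbon, here on a saturated chain carbon bound to a saturated ring carbon. Starting from compound 3, a step of about a 1.7-fold higher number from compound 3 to compound 4 (0.23 log units; within the scatter) is expected, resting on the weakening seen in an at least 1.4-fold higher number from compound 1 to compound 2 (0.17 log units; that floor lies within the scatter), whose floor lies within the scatter. Compound 4 is therefore estimated at 2200 nM in this assay, between 900 nM and 5500 nM.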

Compound 4, half-maximal inhibitory concentration: > 10000 nM
Compound 4: only a limit was reported (the forecaster's own chance of this, stated with the estimate: 10%); middle value at least 4.5-fold (0.65 log units) away from the limit.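

In this assay, methyl in place of hydrogen on a saturated chain carbon bound to a saturated ring carbon gave an at least 7.6-fold higher number from compound 3 to compound 4 (0.88 log units; beyond the scatter). On these data alone, the read-out of compound 4, > 10000 nM, is a limit of the assay and not a number, so this step is a floor and its true size is unknown. Beside the earlier step, this shows that the change raises the number beyond the scatter on the core of compound 3, but it does not show that the size of the step carries from one core to the other, or that the two cores respond differently: the same change on two cores in this assay, an at least 1.4-fold higher number (0.17 log units; that floor lies within the scatter) from compound 1 to compound 2 and an at least 7.6-fold higher number (0.88 log units; beyond the scatter) from compound 3 to compound 4; the limit leaves it open whether they differ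

As far as these compounds go, how far compound 2 and compound 4 lie past the limit remains open, and with it any comparison of the two steps: the limit of > 10000 nM in this assay, at which 2 of the 4 values shown sit. Also open is whether an amine or a carboxylic acid on that chain, in place of the added methyl, would keep the read-out near that of compound 3.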